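Compound 3 to compound 4: chloro to bromo

This account rests on a few compounds, and the source may have more. Where it says the series, first, only, none or still open, it means among the compounds named here.

In a functional assay on QGY-7703 cells (Homo sapiens) for cytotoxicity, read by MTT assay, with a stated time of 24 h (on this read-out higher numbers stand for weaker inhibition and lower numbers for stronger inhibition), compound 3 (`O=C1/C(=C/c2ccncc2)CN(S(=O)(=O)c2ccc(Cl)cc2)C/C1=C\c1ccccc1C(F)(F)F`) gives 12700 nM, and compound 1 (`CN1C/C(=C\c2ccncc2)C(=O)/C(=C/c2ccccc2C(F)(F)F)C1`) reads lower at 4500 nM. For the measured compounds named here, the one measured step, a 2.8-fold higher number from compound 1 to compound 3 (0.45 log units; beyond the scatter), puts (4-chlorophenyl)sulfonyl in place of methyl on an amine nitrogen in a ring, so it says little about a halogen swap. Compound 4 (`O=C1/C(=C/c2ccncc2)CN(S(=O)(=O)c2ccc(Br)cc2)C/C1=C\c1ccccc1C(F)(F)F`) has bromo in place of chloro on an aromatic carbon. Going by the values given here, no measured step makes this swap. Compound 2 (`O=C1/C(=C/c2ccncc2)CN(S(=O)(=O)c2ccc(Br)cc2)C/C1=C\c1ccccc1F`) already carries (4-bromophenyl)sulfonyl, with fluoro instead of trifluoromethyl, and its 11500 nM lies within the scatter of compound 3. No change beyond the scatter is therefore expected. The expected step is a 1.0-fold lower number from compound 3 to compound 4 (0.01 log units; within the scatter). Compound 4 is estimated at 12500 nM, with an expected range of 7500 nM to 20000 nM.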

Compound 4, half-maximal inhibitory concentration: 7060 nM
Compound 4: the middle estimate sits 1.8-fold (0.25 log units) above what was measured; the measured number lies below the stated range.
By their numbers in this assay, from the lowest: compounds 1, 4, 2 and 3 (each within the scatter of the next, the first and the last beyond it).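

In this assay, bromo in place of chloro gives a 1.8-fold lower number from compound 3 to compound 4 (0.25 log units; within the scatter), and trifluoromethyl in place of fluoro gives a 1.6-fold lower number from compound 2 to compound 4 (0.21 log units; within the scatter), so neither change separates these compounds. Replacing methyl with (4-bromophenyl)sulfonyl gives a 1.6-fold higher number from compound 1 to compound 4 (0.20 log units; within the scatter), so the step beyond the scatter seen with (4-chlorophenyl)sulfonyl is not repeated with the bromo analogue. Nothing available bears on the reason for these steps. Going by these compounds, whether an amine or a carboxylic acid on that aromatic carbon would give a step beyond the scatter remains open.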